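Thiosemicarbazone series: aryl substituent and Vero cytotoxicity

The source may report more compounds than this note shows. Statements on the series, on what has been measured and on what is new or still open speak of the compounds shown alone.

Measured so far in an ADME assay on Vero cells (Chlorocebus sabaeus) for cytotoxicity, read by MTT assay, with a stated time of 72 h; on this read-out higher numbers stand for lower toxicity in this test and lower numbers for higher toxicity in this test:
compound 1 `C/C(=N/NC(=S)N(Cc1ccccc1)Cc1ccccc1)c1ccc(N)cc1` gives 161000 nM
compound 2 `C/C(=N/NC(=S)N(Cc1ccccc1)Cc1ccccc1)c1ccc(F)cc1` gives 160000 nM
compound 3 `C/C(=N/NC(=S)N(Cc1ccccc1)Cc1ccccc1)c1ccccc1` gives 167000 nM

Compound 3, the unsubstituted parent of the three, sits within the scatter of both others in this assay : the step of a 1.0-fold higher number from compound 1 to compound 3 (0.02 log units; within the scatter) and the step of a 1.0-fold higher number from compound 2 to compound 3 (0.02 log units; within the scatter) are both too small to count. The third pair behaves the same way, with a 1.0-fold lower number from compound 1 to compound 2 (0.00 log units; within the scatter). Across the three compounds the substituent on the aromatic ring has so far made no difference that the test can resolve.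

Compound 4 `C/C(=N/NC(=S)N(Cc1ccccc1)Cc1ccccc1)c1ccc([N+](=O)[O-])cc1` is the next member, still unmeasured in this assay. Against compound 3 the change is nitro in place of hydrogen on an aromatic carbon. Among the measured compounds shown here, no step with a nitro group exists, so the nearest guidance comes from the three substituent exchanges at the same position, each of which stayed within the scatter. On that basis the step from compound 3 to compound 4 is expected to be a 1.0-fold lower number from compound 3 to compound 4 (0.02 log units; within the scatter), with no direction favoured beyond the noise. Compound 4 is therefore estimated at 160000 nM in this assay, within a range from 80000 nM to 320000 nM.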

Compound 4, half-maximal cytotoxic concentration: < 150000 nM
Compound 4 ended at the assay's limit; the forecaster's own chance of this, stated with the estimate: 15%; middle value at least 1.0-fold (0.02 log units) from the limit.
By their numbers in this assay, from the lowest: compounds 2, 1 and 3 (each within the scatter of the next). At a limit, below all of these: compound 4.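

In this assay compound 4 gives < 150000 nM, which is a limit of the assay and not a number. Nitro is the first group at this aromatic carbon, para to a large group, to return no resolved value, so the new steps are floors only: an at least 1.1-fold lower number from compound 3 to compound 4 (0.04 log units; that floor lies within the scatter), an at least 1.0-fold lower number from compound 2 to compound 4 (0.02 log units; that floor lies within the scatter) and an at least 1.0-fold lower number from compound 1 to compound 4 (0.03 log units; that floor lies within the scatter) each lie within the scatter at that floor, and they establish neither a real change nor its absence. Where hydrogen, fluoro and amino gave three numbers within the scatter of each other, this position now also holds one open-ended result, the only one of its kind in the set: the limit of < 150000 nM in this assay, at which 1 of the 4 values shown sits.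

The true distance of compound 4 from the other three remains unread, so it is still unsettled whether any exchange at this carbon moves the read-out beyond the scatter. Also open, on these data alone, are how a carboxylic acid or a nitrile would read at this same carbon, and whether changes elsewhere on the shared core would give a resolvable difference.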